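Carbonyl-side aryl variation on the shared core

This account rests on a few compounds, and the source may have more. Where it says the series, first, only, none or still open, it means among the compounds named here.

Compound 1 `CCCCOc1ccc(C(=O)/C=C/c2c(/C=C/c3ccc(OC)cc3)cc(OC)cc2OC)cc1` gives 12.9 ug/mL in a functional assay on HepG2 cells (Homo sapiens) for antiproliferative activity, read by MTT assay, with a stated time of 48 h; a lower number here means a stronger inhibitor, a higher number a weaker inhibitor.
Compound 2 `COc1ccc(/C=C/c2cc(OC)cc(OC)c2/C=C/C(=O)c2ccc(F)cc2)cc1` gives 12.2 ug/mL.
Compound 3 `COc1ccc(/C=C/c2cc(OC)cc(OC)c2/C=C/C(=O)c2cccc(OC)c2)cc1` gives 11.6 ug/mL.

Compound 1 holds the highest of the three numbers, yet the steps of a 1.1-fold lower number from compound 1 to compound 2 (0.02 log units; within the scatter) and a 1.1-fold lower number from compound 1 to compound 3 (0.05 log units; within the scatter) both fall within the scatter, as does a 1.1-fold lower number from compound 2 to compound 3 (0.02 log units; within the scatter), so no ordering among the three can be read. Compound 4 `COc1ccc(/C=C/c2cc(OC)cc(OC)c2/C=C/C(=O)c2ccc(-c3ccccc3)cc2)cc1` differs from compound 1 by phenyl in place of butoxy on an aromatic carbon. The measured steps that bear on it all exchange the group on the carbonyl-bearing aryl ring, and none moved the number beyond the scatter. A phenyl in place of butoxy is a larger exchange than any of those, so the range is set somewhat wider, but no step beyond the scatter is expected: a 1.1-fold lower number from compound 1 to compound 4 (0.03 log units; within the scatter). Compound 4 is estimated at 12 ug/mL, between 5 ug/mL and 30 ug/mL.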

Compound 4, half-maximal inhibitory concentration: 10.5 ug/mL
Beside the measured number, compound 4's estimate is 1.1-fold (0.06 log units) above it, within the range that was stated.
By their numbers in this assay, from the lowest: compounds 4, 3, 2 and 1 (each within the scatter of the next).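

Phenyl, a ring group, takes the place of butoxy or fluoro on an aromatic carbon para to a large group, and neither exchange leaves the scatter (first a 1.2-fold lower number from compound 1 to compound 4 (0.09 log units; within the scatter), then a 1.2-fold lower number from compound 2 to compound 4 (0.07 log units; within the scatter)). The 4-phenylphenyl group in place of 3-methoxyphenyl on the carbonyl carbon also stays within it (a 1.1-fold lower number from compound 3 to compound 4 (0.04 log units; within the scatter)), so all four carbonyl-side aryl groups remain indistinguishable in this assay. No available evidence bears on this result.

Open, going by these compounds, is whether an amine or a carboxylic acid at this position would give a step beyond the scatter. Changes to the methoxy groups of the shared core also remain open.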